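The compounds below may be only part of what the source reports. "The series", "measured", "known", "first", "only" and "open" are said of these compounds alone.

In a functional assay on SK-OV-3 cells (Homo sapiens) for antiproliferative activity, read by luminescence and CellTiter-Glo, with a stated time of 72 h (a lower number here means a stronger inhibitor of growth, a higher number a weaker inhibitor of growth), two compounds with the same core have been measured so far. Compound 1 `N#Cc1ccccc1-n1cc(-c2n[nH]c3cc(Cl)c(N[C@@H]4CCNC4)cc23)cn1`, bearing 2-cyanophenyl on an aromatic nitrogen, gives 2780 nM. Compound 2 `N#Cc1ccc(-n2cc(-c3n[nH]c4cc(Cl)c(N[C@@H]5CCNC5)cc34)cn2)cc1`, bearing 4-cyanophenyl there, gives 52.9 nM, the lower of the two numbers. Among the compounds with values here, the only measured step is large: a 53-fold lower number from compound 1 to compound 2 (1.72 log units; beyond the scatter). Compound 3 `COc1ccc(-n2cc(-c3n[nH]c4cc(Cl)c(N[C@@H]5CCNC5)cc34)cn2)cc1` differs from compound 2 in one group: methoxy in place of cyano on an aromatic carbon. Methoxy stands in place of cyano on an aromatic carbon, para to a large group, turning 4-cyanophenyl into 4-methoxyphenyl. The measured step bears on this only indirectly, since it moves the cyano group and replaces nothing. It shows that changes on this ring can matter, but it gives no direction for methoxy. A modest rise in the number is therefore expected, with real uncertainty. The expected change is a 1.9-fold higher number from compound 2 to compound 3 (0.28 log units; within the scatter). For compound 3, the estimated value is 100 nM, with an expected range from 30 nM to 350 nM.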

Compound 3, concentration for 50% growth inhibition: 718 nM
The estimate for compound 3 lay 7.2-fold (0.86 log units) below the measured number, and the stated range ends below it.
By their numbers in this assay, from the lowest: compound 2; then compound 3; then compound 1.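

In this assay it now turns out that the identity of the group matters, not only where the cyano group sits: methoxy in place of cyano on this aromatic carbon brings a 14-fold higher number from compound 2 to compound 3 (1.13 log units; beyond the scatter) even though the two groups have the same count of heavy atoms and of hydrogen-bond acceptors. Measured against 2-cyanophenyl, the 4-methoxyphenyl group still comes out ahead with a 3.9-fold lower number from compound 1 to compound 3 (0.59 log units; beyond the scatter) and that step is only modest. Nothing measured here explains why swapping these two groups changes the number so much.

As far as these compounds go, it remains open whether cyano is unusual at this place or whether other groups, such as an amine, a carboxylic acid or a single fluorine atom, would give numbers nearer compound 2 or nearer compound 3.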